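Moving the hydroxyl around the anilide ring of compound 2

The source may hold more compounds than are shown below. What is called first, only, known or untested is meant among the compounds shown, and "the series" means these compounds.

Measured so far:
compound 1, `CN(C)C(=O)c1cc2cnc(Nc3ccc(NC(=O)C4(C(=O)Nc5ccccc5F)CC4)cc3)nc2n1C1CCCC1`: 85.2%
compound 2, `CN(C)C(=O)c1cc2cnc(Nc3ccc(NC(=O)C4(C(=O)Nc5cccc(O)c5)CC4)cc3)nc2n1C1CCCC1`: 80.7%
compound 3, `CN(C)C(=O)c1cc2cnc(Nc3ccc(NC(=O)C4(C(=O)Nc5ccc(Br)cc5)CC4)cc3)nc2n1C1CCCC1`: 21.1%

In a functional assay on T47D cells (Homo sapiens) for inhibition, read by CCK-8 assay, with a stated time of 72 h, tested at 1 uM (a higher number here means more inhibition of growth at the concentration tested, a lower number less inhibition of growth), compound 2 gives 80.7%, the second highest of the three numbers. Compound 1 sits closest, with a number 4.5 percentage points lower from compound 1 to compound 2 (within the scatter), while compound 3 lies far off, with a number 59.6 percentage points lower from compound 2 to compound 3 (beyond the scatter). The shared core is unchanged across the set; only the aryl group on the outer amide-type nitrogen varies.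

Compound 4, `CN(C)C(=O)c1cc2cnc(Nc3ccc(NC(=O)C4(C(=O)Nc5ccc(O)cc5)CC4)cc3)nc2n1C1CCCC1`, has not yet been measured. Compared with compound 2 the change is 4-hydroxyphenyl in place of 3-hydroxyphenyl on an amide-type nitrogen.

Within the data shown here, no measured step moves a hydroxyl from one ring position to another, so the expectation rests on indirect evidence. Among the measured compounds shown here, the only compound bearing a group at the same ring position as the entering 4-hydroxyphenyl is compound 3, and the steps of a number 64.1 percentage points lower from compound 1 to compound 3 (beyond the scatter) and a number 59.6 percentage points lower from compound 2 to compound 3 (beyond the scatter) were both large drops. Bromine and hydroxyl are different groups, however, so that drop need not carry over. Compound 4 is therefore expected to land somewhat lower than compound 2, with the estimated step being a number 25.7 percentage points lower from compound 2 to compound 4 (beyond the scatter) and wide uncertainty. The estimate for compound 4 is 55%, within a range of 15% to 85%.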

Compound 4, percent growth inhibition at one concentration: 91.5%
Compound 4: middle estimate off by 36.5 percentage points, on the low side, outside the stated range (above it).
By their numbers in this assay, from the lowest: compound 3; then compounds 2, 1 and 4 (each within the scatter of the next, the first and the last beyond it).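

In this assay moving the hydroxyl alone changes the reading: 4-hydroxyphenyl in place of 3-hydroxyphenyl on the amide-type nitrogen gives a number 10.8 percentage points higher from compound 2 to compound 4 (beyond the scatter), a modest step between two groups with the same atoms. The low reading with 4-bromophenyl therefore does not hold for every group placed as in that name, since hydroxy in place of bromo on the aromatic carbon gives a number 70.4 percentage points higher from compound 3 to compound 4 (beyond the scatter). Against the 2-fluorophenyl group, the new group gives a number 6.3 percentage points higher from compound 1 to compound 4 (within the scatter), so these two cannot be told apart here.

Nothing available explains these differences. As far as these compounds go, whether 4-aminophenyl or 4-methoxyphenyl on the same amide-type nitrogen would read like the hydroxyl or like the bromo compound remains open.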